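The source may report more compounds than this note shows. Statements on the series, on what has been measured and on what is new or still open speak of the compounds shown alone.

Compound 1, `C=Cc1ccc(-c2cc(C)c3ncc(CSCc4ccccc4)n3c2)cc1`, and compound 2, `Cc1cc(N2CCN(C)CC2)cn2c(CSCCc3ccccc3)cnc12`, share a core, and compound 3, `Cc1cc(C#N)cn2c(CSCCc3ccccc3)cnc12`, is still unmeasured. In an ADME assay on HEL cells (Homo sapiens) for cytotoxicity, with a stated time of 3 days (a lower number here means that less compound is tolerated, a higher number that more compound is tolerated), compound 1 reaches only the assay limit of >= 100 ug/mL. In this assay compound 2 gives 20 ug/mL, the only plain number shown. The other value is a limit, (the limit of >= 100 ug/mL in this assay, at which 1 of the 2 values shown sits), belonging to compound 1. Compound 3 differs from compound 2 by cyano in place of 4-methylpiperazin-1-yl on an aromatic carbon. Going by the values given here, no measured pair shows this change, so the step from compound 2 to compound 3 in this assay is expected to be modest, toward more compound tolerated. The expected step is a 2.5-fold higher number from compound 2 to compound 3 (0.40 log units; beyond the scatter). Compound 3 is estimated at 50 ug/mL, likely between 15 ug/mL and 100 ug/mL.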

Compound 3, minimum cytotoxic concentration: 20 ug/mL
The estimate for compound 3 lay 2.5-fold (0.40 log units) above the measured number; the measured number falls inside the stated range.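

At this position, on an aromatic carbon two atoms from the ring nitrogen, replacing 4-methylpiperazin-1-yl with the cyano group, which has far fewer heavy atoms, gives in this assay no change at the digits printed from compound 2 to compound 3 (within the scatter). In this one pair, the reading does not depend on keeping the six-membered non-aromatic ring. Nothing shown gives a cause for this result. On these data alone, whether a primary amine or a carboxylic acid at this position would give a similar reading remains open, as does whether the same holds with a different chain on the sulfur.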